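Expected Clearance after Swapping the Side Group of Compound 2

This account rests on a few compounds, and the source may have more. Where it says the series, first, only, none or still open, it means among the compounds named here.

Measured so far in an ADME assay on microsomes from liver (Rattus norvegicus) for metabolic stability, read by LC-MS; on this read-out lower numbers stand for slow clearance and higher numbers for fast clearance:
compound 1 `COc1cc(N2CCN(C(=O)N[C@@H](C)c3cccc4ccccc34)CC2)ccc1-n1cc(C)nn1`: 230 mL.min-1.g-1
compound 2 `COc1cc(N2CCN(C(=O)CN3Cc4ccccc4C3)CC2)ccc1-c1cnc(C)o1`: 42 mL.min-1.g-1
compound 3 `COc1cc(N2CCN(C(=O)N[C@@H](C)c3cccc4ccccc34)CC2)ccc1-n1cnc(C)c1`: 150 mL.min-1.g-1

Among these three, compound 2 gives the lowest number, and its gaps to compound 3 and to compound 1 both lie beyond the usual scatter. Going by the values given here, the only step between compounds that differ in one place is a 1.5-fold lower number from compound 1 to compound 3 (0.19 log units; within the scatter), a swap of one heteroaryl ring on an aromatic carbon of the shared core.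

Compound 4 `COc1cc(N2CCN(C(=O)Cn3cnc4ccccc43)CC2)ccc1-c1cnc(C)o1` differs from compound 2 at another place: a group of 9 heavy atoms (7 carbon, 2 nitrogen; one five-membered aromatic ring with 2 hetero atoms, one six-membered aromatic ring of carbon only) in place of a group of 9 heavy atoms (8 carbon, 1 nitrogen; one five-membered non-aromatic ring with 1 hetero atom, one six-membered aromatic ring of carbon only), on a saturated chain carbon bound to a carbonyl carbon. Among the compounds with values here, no measured step touches this position, so the measured step from compound 1 to compound 3 gives no direct guide; it only shows that one ring swap elsewhere on the core stayed within the scatter. With nothing pointing either way, compound 4 is expected to stay close to compound 2 in this assay, with a step of a 1.2-fold higher number from compound 2 to compound 4 (0.08 log units; within the scatter) that is expected to fall within the scatter. The estimate for compound 4 is therefore 50 mL.min-1.g-1, expected between 20 mL.min-1.g-1 and 130 mL.min-1.g-1.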

Compound 4, intrinsic clearance in microsomes: 22 mL.min-1.g-1
Compound 4: the middle estimate sits 2.3-fold (0.36 log units) above what was measured; measured number inside the range.
By their numbers in this assay, from the lowest: compounds 4 and 2 (each within the scatter of the next); then compounds 3 and 1 (each within the scatter of the next).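

At this position, on a saturated chain carbon bound to a carbonyl carbon, 1H-benzimidazol-1-yl replaces a group of the same heavy-atom count, and this assay shows a 1.9-fold lower number from compound 2 to compound 4 (0.28 log units; within the scatter). Going by these compounds alone, this is the first measured step here, and it shows that a five-membered aromatic ring with 2 hetero atoms can take the place of a five-membered non-aromatic ring with 1 hetero atom without a step beyond the scatter. Nothing else measured on these compounds bears on this result.

Still open, from the compounds shown here alone, is whether a quite different group on this carbon, such as a simple amine or a carboxylic acid, would also stay within the scatter. Also open, going by these compounds, is whether the same swap would give a similar step with the 4-methyl-1H-imidazol-1-yl of compound 3 on the shared core.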